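Isobutyl gives way to tert-butyl on the shared core

The compounds below may be only part of what the source reports. "The series", "measured", "known", "first", "only" and "open" are said of these compounds alone.

In a functional assay on brain (Rattus norvegicus, strain Wistar) for inhibition (on this read-out higher numbers stand for weaker inhibition and lower numbers for stronger inhibition), compound 1 (`Cc1ccc(-c2c(C)[nH]c(=O)n2C)cc1`) gives 85300 nM as its result. Compound 2 (`CCCc1ccc(-c2c(C)[nH]c(=O)n2C)cc1`) gives 21500 nM here, and compound 3 (`Cc1[nH]c(=O)n(C)c1-c1ccc(CC(C)C)cc1`) gives 7800 nM as the lowest number of the three, so it inhibits most strongly so far. Across these three compounds, a larger chain went with a lower number. The record shows a 4.0-fold lower number from compound 1 to compound 2 (0.60 log units; beyond the scatter) and a 2.8-fold lower number from compound 2 to compound 3 (0.44 log units; beyond the scatter), both modest, which together make an 11-fold lower number from compound 1 to compound 3 (1.04 log units; beyond the scatter), a large step. Compound 4 (`Cc1[nH]c(=O)n(C)c1-c1ccc(C(C)(C)C)cc1`) has the same atoms as compound 3, joined differently: tert-butyl in place of isobutyl on an aromatic carbon. This puts tert-butyl in place of isobutyl on an aromatic carbon. Among the compounds with values here, each measured step added carbon, whereas this change adds none, so those steps guide only indirectly, and no measured pair shows such a rearrangement. The expected step is a 1.1-fold lower number from compound 3 to compound 4 (0.05 log units; within the scatter), which means none beyond the scatter in either direction. Compound 4 is estimated at 7000 nM, with an expected range from 2500 nM to 22000 nM in this assay as the likely outcome.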

Compound 4, half-maximal inhibitory concentration: 8400 nM
Estimate against measurement, compound 4: 1.2-fold (0.08 log units) below, within the range that was stated.
By their numbers in this assay, from the lowest: compounds 3 and 4 (each within the scatter of the next); then compound 2; then compound 1.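

Within this assay, rearranging the same carbons from isobutyl to tert-butyl on the aromatic carbon gives a 1.1-fold higher number from compound 3 to compound 4 (0.03 log units; within the scatter) and lies within the scatter, so the two groups cannot be told apart here, whereas every earlier step, each of which added carbon, went beyond it. The tert-butyl group still shows a 2.6-fold lower number from compound 2 to compound 4 (0.41 log units; beyond the scatter) and a 10-fold lower number from compound 1 to compound 4 (1.01 log units; beyond the scatter) against the smaller chains, so across these four compounds the number tracks how many carbons the group holds, and how those carbons are joined makes no visible difference between isobutyl and tert-butyl. Nothing available explains this result.

The compounds shown leave open whether a longer chain such as pentyl or a ring such as cyclohexyl would lower the number further. They also leave open how an amine or a carboxylic acid would fare at this place.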